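The source may report more compounds than this note shows. Statements on the series, on what has been measured and on what is new or still open speak of the compounds shown alone.

Compound 1 `CC(C)(C)OC(=O)N1CCC(CCCNc2ccc3c(c2)OCC3=O)CC1`: 66 nM
Compound 2 `COC(=O)c1cnc(N2CCC(CCCNc3ccc4c(c3)OCC4=O)CC2)nc1`: 139 nM

Within the data shown here, in a functional assay on CHO-K1 cells for agonist activity at Glucose-dependent insulinotropic receptor (Mus musculus), read by HTRF and cAMP accumulation, with a stated time of 30 min (a higher number here means that more compound is needed for the effect, a lower number that less compound is needed), compound 2 stands highest of the two numbers, its only neighbour being compound 1 by the step of a 2.1-fold higher number from compound 1 to compound 2 (0.32 log units; beyond the scatter). Compound 3 `CC(C)c1nnc(N2CCC(CCCNc3ccc4c(c3)OCC4=O)CC2)o1` is not yet measured in this assay. It differs from compound 2 by 5-isopropyl-1,3,4-oxadiazol-2-yl in place of 5-(methoxycarbonyl)pyrimidin-2-yl on an amine nitrogen in a ring. Among the measured compounds shown here, the single measured step bears on it only as a change at the same ring nitrogen with a different group, and no measured compound carries the entering group. Compound 3 is therefore expected to give a step of a 1.5-fold lower number from compound 2 to compound 3 (0.17 log units; within the scatter), small and possibly within the scatter. The estimate for compound 3 is 95 nM, in the range 35 nM to 260 nM.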

Compound 3, half-maximal effective concentration: 1020 nM
Compound 3: the middle estimate sits 11-fold (1.03 log units) below what was measured; the measured number lies above the stated range.
By their numbers in this assay, from the lowest: compound 1; then compound 2; then compound 3.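

In this assay, the group on this amine nitrogen in a ring proves able to shift the number much further than the first pair showed: 5-isopropyl-1,3,4-oxadiazol-2-yl gives a 7.3-fold higher number from compound 2 to compound 3 (0.87 log units; beyond the scatter) and a 15-fold higher number from compound 1 to compound 3 (1.19 log units; beyond the scatter). Both aromatic heterocycles are thus not interchangeable here, and of the three groups, tert-butoxycarbonyl gives the lowest number. Nothing available explains the larger step. Going by these compounds, it remains open whether the rise follows the five-membered aromatic ring or its isopropyl group; a cyclopropyl or tert-butyl on that ring could separate the two.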